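From (methylamino)methyl to fluoro

The source may report more compounds than this note shows. Statements on the series, on what has been measured and on what is new or still open speak of the compounds shown alone.

Measured in an ADME assay on microsomes from liver (Rattus norvegicus) for metabolic stability; a lower number here means that the compound disappears faster, a higher number that the compound lasts longer:
compound 1 `Cn1nc2c(=O)n(CC3(O)CCN(Cc4ccc(-c5ccco5)cc4Cl)CC3)cnc2c1-c1ccc(CNCCO)cc1`: 1.52 h
compound 2 `CNCc1ccc(-c2c3ncn(CC4(O)CCN(Cc5ccc(-c6ccco6)cc5Cl)CC4)c(=O)c3nn2C)cc1`: 0.533 h

Of the two, compound 2 has the lower number, 0.533 h. Compound 3 `Cn1nc2c(=O)n(CC3(O)CCN(Cc4ccc(-c5ccco5)cc4Cl)CC3)cnc2c1-c1ccc(F)cc1` carries fluoro in place of (methylamino)methyl on an aromatic carbon, para to a large group (fluoro in place of (methylamino)methyl on an aromatic carbon). Within the data shown here, one measured step bears on this, and only loosely: a 2.9-fold lower number from compound 1 to compound 2 (0.46 log units; beyond the scatter). It was modest and put hydrogen in place of hydroxymethyl within the same side chain, whereas the new change removes the whole group. Going by these compounds, no step beyond the scatter is therefore expected in this assay, though either direction remains open. The expected change is a 1.1-fold lower number from compound 2 to compound 3 (0.03 log units; within the scatter). For compound 3 the estimate is 0.5 h, with an expected range of 0.17 h to 1.5 h.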

Compound 3, half-life: 0.75 h
The estimate for compound 3 lay 1.5-fold (0.18 log units) below the measured number; the range from low to high includes it.
By their numbers in this assay, from the lowest: compounds 2 and 3 (each within the scatter of the next); then compound 1.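

In this assay, fluoro in place of the whole (methylamino)methyl group on this aromatic carbon gives a 1.4-fold higher number from compound 2 to compound 3 (0.15 log units; within the scatter), so removing that group makes no difference beyond the scatter. Fluoro in place of ((2-hydroxyethyl)amino)methyl gives a 2.0-fold lower number from compound 1 to compound 3 (0.31 log units; beyond the scatter), a modest step, and at this position only that group stands apart from fluoro. Nothing available accounts for this result. The compounds shown leave open whether a carboxylic acid, an ether or a longer chain on this carbon would give a number like that of compound 1.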